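Hydroxymethyl for Trifluoromethyl: Expected Half-Life of Compound 4

The compounds below may be only part of what the source reports. "The series", "measured", "known", "first", "only" and "open" are said of these compounds alone.

Compound 1, `Cc1cc(CCC#N)cc(C)c1Oc1cc(Nc2ccc(C#N)cc2)c(N)cc1C(F)(F)F`: 0.928 h
Compound 2, `Cc1cc(/C=C/C#N)cc(C)c1Oc1cc(Nc2ccc(C#N)cc2)c(N)cc1C(F)(F)F`: 0.75 h
Compound 3, `Cc1cc(/C=C/C#N)cc(C)c1Oc1cc(Nc2ccc(C#N)cc2)c(N)cc1[N+](=O)[O-]`: 0.797 h

Of the compounds shown here, three sharing one core have been measured in an in vitro ADME assay on microsomes from liver (Homo sapiens) for metabolic stability, tested at 1 uM; on this read-out higher numbers stand for a longer-lived compound and lower numbers for a shorter-lived compound. The numbers of compound 1, compound 3 and compound 2 differ from one another by less than the usual scatter, so all three sit within the scatter of one another. Along the measured steps, a 1.2-fold lower number from compound 1 to compound 2 (0.09 log units; within the scatter) and a 1.1-fold higher number from compound 2 to compound 3 (0.03 log units; within the scatter), neither change moved the read-out beyond the scatter.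

Compound 4, `Cc1cc(CCC#N)cc(C)c1Oc1cc(Nc2ccc(C#N)cc2)c(N)cc1CO`, has not yet been measured. It differs from compound 1 in one place: hydroxymethyl in place of trifluoromethyl on an aromatic carbon. For the measured compounds named here, the only measured step at this same position, a 1.1-fold higher number from compound 2 to compound 3 (0.03 log units; within the scatter), replaced the same leaving group with a different entering group and left the half-life essentially unchanged. Going by the values given here, no measured step involves a hydroxymethyl group, so the data give no direct guidance on this entering group. On the basis of compound 1 at 0.928 h and the flat response seen so far, compound 4 is expected to show a 1.2-fold lower number from compound 1 to compound 4 (0.09 log units; within the scatter), a step not beyond the scatter. The estimated half-life of compound 4 is therefore 0.75 h, within a range of 0.4 h to 1.4 h.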

Compound 4, half-life: 0.348 h
For compound 4 the middle estimate is 2.2-fold (0.33 log units) above the measured one, and the stated range ends above it.
By their numbers in this assay, from the lowest: compound 4; then compounds 2, 3 and 1 (each within the scatter of the next).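

In this assay the change of trifluoromethyl to hydroxymethyl gave a 2.7-fold lower number from compound 1 to compound 4 (0.43 log units; beyond the scatter) and is the first change at this position among the compounds shown to move the half-life beyond the scatter. The earlier change at this position, a 1.1-fold higher number from compound 2 to compound 3 (0.03 log units; within the scatter) and thus within the scatter, showed only that nitro and trifluoromethyl could not be told apart here, so the flat response does not extend to every group placed on this aromatic carbon. Nothing measured here explains why the half-life of compound 4 is shorter, and the step itself gives only its size and direction.

As far as these compounds go, it remains open whether the result follows from the hydrogen-bond donor and acceptor that hydroxymethyl brings, from the loss of the fluorine atoms, or from something else, and whether the same change would have a similar effect on compound 2, which carries 2-cyanoethenyl in place of 2-cyanoethyl. A methoxymethyl group, an aminomethyl group, a carboxylic acid or a longer chain such as hydroxyethyl at this position also lies outside the compounds shown, so how the half-life responds to such groups is unknown.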